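Replacing Dimethoxyphenyl with Hydroxymethylphenyl on a Shared Core

The source may report more compounds than this note shows. Statements on the series, on what has been measured and on what is new or still open speak of the compounds shown alone.

Compound 1, `Cc1ccc(CNc2ncnc3c2ncn3[C@@H]2O[C@H](CO)[C@@H](O)[C@H]2O)cc1`, gives in a functional assay on HL-60 cells (Homo sapiens) for antiproliferative activity, with a stated time of 72 h (on this read-out higher numbers stand for weaker inhibition and lower numbers for stronger inhibition), only a limit, > 166000 nM.
Compound 2, `OC[C@H]1O[C@@H](n2cnc3c(NCc4ccc(Cl)cc4Cl)ncnc32)[C@H](O)[C@@H]1O`, gives in this assay the number 96300 nM.
Compound 3, `COc1cccc(CNc2ncnc3c2ncn3[C@@H]2O[C@H](CO)[C@@H](O)[C@H]2O)c1OC`, gives in this assay only a limit, > 166000 nM.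

Compound 3 thus stands at the edge of what this assay can report, and it is not alone there: the limit of > 166000 nM in this assay, at which 2 of the 3 values shown sit. Compound 4, `Cc1cccc(CNc2ncnc3c2ncn3[C@@H]2O[C@H](CO)[C@@H](O)[C@H]2O)c1O`, has not yet been measured. It differs from compound 3 in one place: 2-hydroxy-3-methylphenyl in place of 2,3-dimethoxyphenyl on a saturated chain carbon bound to a nitrogen on an aromatic ring.

For the measured compounds named here, two measured steps bear on this change, both ending at compound 3. The step that the two limits leave unreadable from compound 1 to compound 3 cannot be sized, since both ends are limits. The step of an at least 1.7-fold higher number from compound 2 to compound 3 (0.23 log units; that floor lies within the scatter) has a floor that lies within the scatter. Neither step shows a change in the aromatic group on the saturated chain carbon moving the read-out clearly, and both leave compound 3 at the limit.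

The expectation for compound 4 is therefore a read-out near the same limit, with the step of an at least 1.1-fold lower number from compound 3 to compound 4 (0.04 log units; that floor lies within the scatter) not expected to exceed the scatter. Compound 4 is estimated at 150000 nM, within 60000 nM to 400000 nM.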

Compound 4, half-maximal inhibitory concentration: 15000 nM
Compound 4: the middle estimate sits 10-fold (1.00 log units) above what was measured; the whole stated range lies above it.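

On the saturated chain carbon bound to a nitrogen on an aromatic ring, a change of aromatic group now moves the read-out in this assay beyond the scatter, which no earlier step had shown: exchanging 2,3-dimethoxyphenyl for 2-hydroxy-3-methylphenyl gives an at least 11-fold lower number from compound 3 to compound 4 (1.04 log units; beyond the scatter) and the same group set against 4-methylphenyl gives an at least 11-fold lower number from compound 1 to compound 4 (1.04 log units; beyond the scatter) on the shared core. For the compounds shown here, the gain also holds against the only earlier compound with a measured number, with a 6.4-fold lower number from compound 2 to compound 4 (0.81 log units; beyond the scatter) as the one step here that has a number at both ends, so 2-hydroxy-3-methylphenyl outperforms 2,4-dichlorophenyl as well. On these data alone, the other two steps are floors whose full size stays unknown, since each starts from a compound held at a limit: the limit of > 166000 nM in this assay, at which 2 of the 4 values shown sit.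

The compounds shown leave open whether the hydroxy group or the methyl group of 2-hydroxy-3-methylphenyl carries this step, as the two never appear apart on this position. Going by these compounds alone, they also cannot tell whether an amine or a carboxylic acid in place of that hydroxy group would keep the gain, and even compound 4 remains a weak inhibitor only in the sense of its single printed number.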